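Bromo for fluoro on a cyclopropylamino core

A few compounds are considered here, and "the series" means these few. Any claim that something is new, unique, unknown or untested is made for them only; others in the source may bear on it.

Compound 1, `CC(C)NC1=NS(=O)(=O)c2cc(F)ccc2N1`, in a functional assay (aorta) with Rattus norvegicus as the target (on this read-out higher numbers stand for an effect only at larger amounts of compound and lower numbers for an effect already at smaller amounts), gives 43.1 uM.
Compound 3, `CC(C)NC1=NS(=O)(=O)c2cc(Br)ccc2N1`, in this assay gives 4.8 uM.
Compound 2, `O=S1(=O)NC(NC2CC2)=Nc2ccc(F)cc21`, in this assay gives > 300 uM, which is a limit of the assay and not a number.

The difference between the core of compound 1 and the core of compound 2 is not broken down here. From compound 1 to compound 3 the change is bromo in place of fluoro on an aromatic carbon, and the step is a 9.0-fold lower number from compound 1 to compound 3 (0.95 log units; beyond the scatter). Compound 4, `O=S1(=O)NC(NC2CC2)=Nc2ccc(Br)cc21`, is not yet measured; it differs from compound 2 by the same change, (bromo in place of fluoro on an aromatic carbon). For compound 4 a step of an at least 5.0-fold lower number from compound 2 to compound 4 (0.69 log units; beyond the scatter) in this assay is expected, resting on the step from compound 1 to compound 3, though because compound 2 sits at the limit of > 300 uM in this assay, at which 1 of the 3 values shown sits, the starting point is uncertain. The estimate for compound 4 is 60 uM, within 15 uM and 300 uM.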

Compound 4, concentration for half-maximal effect: 89.4 uM
Estimate against measurement, compound 4: 1.5-fold (0.17 log units) below; the measured number falls inside the stated range.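

In this assay, bromo in place of fluoro on an aromatic carbon again goes with a lower number on the second core, with an at least 3.3-fold lower number from compound 2 to compound 4 (0.52 log units; beyond the scatter). The change thus points the same way on both cores, but this does not show that its size carries over: the same change on two cores in this assay, a 9.0-fold lower number (0.95 log units; beyond the scatter) from compound 1 to compound 3 and an at least 3.3-fold lower number (0.52 log units; beyond the scatter) from compound 2 to compound 4; the limit leaves it open whether they differ. From the compounds shown here alone, compound 2 gives > 300 uM, which is a limit of the assay and not a number, so the true size of the step on this core remains unknown.

The compounds shown leave open how chloro or methoxy on that aromatic carbon would read in this assay. They also leave open what a longer chain on the amino group would do on either core.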